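The source may report more compounds than this note shows. Statements on the series, on what has been measured and on what is new or still open speak of the compounds shown alone.

Cytotoxicity notes on a two-ring biaryl series. Compound 1 `N=C(N)c1ccc(-c2ccc(-c3cc(Cl)cc(Cl)c3)s2)cc1` in an ADME assay on WISH cells (Homo sapiens) for cytotoxicity, read by MTT assay, with a stated time of 24 h (a lower number here means a stronger inhibitor, a higher number a weaker inhibitor), gives 156000 nM. Compound 2 `N=C(N)c1ccc(-c2ccc(-c3ccc(Cl)cc3)s2)cc1F` in this assay gives 64200 nM, the lower of the two numbers, so compound 2 stands as the stronger inhibitor here, with compound 1 showing the higher number. Compound 3 `COc1ccc(-c2ccc(-c3ccc(C(=N)N)c(F)c3)s2)cc1` is the next point and carries methoxy in place of chloro on an aromatic carbon. With no comparable change measured, only a small step is expected, a 1.4-fold higher number from compound 2 to compound 3 (0.15 log units; within the scatter), toward a weaker inhibitor. Compound 3 is therefore estimated at 90000 nM, within 40000 nM to 200000 nM.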

Compound 3, half-maximal inhibitory concentration: 112000 nM
Beside the measured number, compound 3's estimate is 1.2-fold (0.09 log units) below it, within the range that was stated.
By their numbers in this assay, from the lowest: compounds 2, 3 and 1 (each within the scatter of the next, the first and the last beyond it).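

Methoxy in place of chloro, on an aromatic carbon para to a large group, gives the first step in the series that can be read at a single place: a 1.7-fold higher number from compound 2 to compound 3 (0.24 log units; within the scatter) in this assay. At this position, the exchange therefore leaves compound 2 and compound 3 within the scatter of each other. No measured evidence bears on this result.

From the compounds shown here alone, whether an amine or a carboxylic acid at this position would stay within the scatter remains open. The compounds shown also give no single-place step at any other position on the shared core.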